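A few compounds are considered here, and "the series" means these few. Any claim that something is new, unique, unknown or untested is made for them only; others in the source may bear on it.

Compound 1 `CC1(C)C=C(n2ccccc2=O)c2cc(S(=O)(=O)N=[N+]=[N-])ccc2O1` gives 204 nM in a functional assay with Rattus norvegicus as the target; a lower number here means that less compound is needed, a higher number that more compound is needed for the effect. Compound 2 `CC1(C)C=C(n2ccccc2=O)c2cc(S(N)(=O)=O)ccc2O1` gives 224 nM. Compound 3 `CC1(C)C=C(n2ccccc2=O)c2cc(S(=O)(=O)NCCO)ccc2O1` gives 1000 nM.

Compound 2 sits second highest of these three numbers; the nearer step is a 1.1-fold higher number from compound 1 to compound 2 (0.04 log units; within the scatter), while the further step is a 4.5-fold higher number from compound 2 to compound 3 (0.65 log units; beyond the scatter). Compound 4 `CC1(C)C=C(n2ccccc2=O)c2cc(S(=O)(=O)N3CCOCC3)ccc2O1` arises from compound 2 by this change: morpholin-4-yl in place of amino on a sulfonyl sulfur. The step that bears on it is the one that also adds carbon to the sulfonamide nitrogen, a 4.5-fold higher number from compound 2 to compound 3 (0.65 log units; beyond the scatter), echoed by a 4.9-fold higher number from compound 1 to compound 3 (0.69 log units; beyond the scatter). Morpholin-4-yl is a larger addition than 2-hydroxyethyl, and no measured compound shows a ring there. A modest rise is therefore expected, about a 3.6-fold higher number from compound 2 to compound 4 (0.55 log units; beyond the scatter), giving an estimated 800 nM for compound 4, with a range from 300 nM to 2500 nM.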

Compound 4, half-maximal effective concentration: 603 nM
For compound 4 the middle estimate is 1.3-fold (0.12 log units) above the measured one; the measured number falls inside the stated range.
By their numbers in this assay, from the lowest: compounds 1 and 2 (each within the scatter of the next); then compounds 4 and 3 (each within the scatter of the next).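

Both a 2.7-fold higher number from compound 2 to compound 4 (0.43 log units; beyond the scatter) and a 3.0-fold higher number from compound 1 to compound 4 (0.47 log units; beyond the scatter) show in this assay that this position on the sulfonyl sulfur accepts a six-membered ring at a modest cost. With a 1.7-fold lower number from compound 3 to compound 4 (0.22 log units; within the scatter) as well, morpholin-4-yl and (2-hydroxyethyl)amino cannot be told apart, so a ring and an open chain on this sulfur give similar numbers. No measurement at hand explains these steps. The compounds shown leave open whether a piperazine, a pyrrolidine or a simple dimethylamino group would give a similar number.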